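This account rests on a few compounds, and the source may have more. Where it says the series, first, only, none or still open, it means among the compounds named here.

In a functional assay on A549 cells (Homo sapiens) for cytotoxicity, read by MTT assay, with a stated time of 72 h (a higher number here means a weaker inhibitor, a lower number a stronger inhibitor), compound 1 (`Cn1ccc2c(Oc3ccc(NC(=O)c4cc5cccnc5n(-c5ccccc5)c4=O)cc3F)ncnc21`) gives 63200 nM and compound 2 (`O=C(Nc1ccc(Oc2ncnc3[nH]ccc23)c(F)c1)c1cc2cccnc2n(-c2ccccc2)c1=O`) gives 45500 nM. For the measured compounds named here, compound 2 therefore stands level with compound 1, the only other compound measured, since the two numbers lie within the scatter of each other. Compound 3 (`O=C(Nc1ccc(Oc2ncnc3[nH]ccc23)c(F)c1)c1cc2cccnc2n(-c2ccc(Cl)cc2)c1=O`) keeps all of compound 2 except that phenyl becomes 4-chlorophenyl: chloro in place of hydrogen on an aromatic carbon. This places chloro in place of hydrogen on an aromatic carbon, para to a large group. Going by the values given here, the only measured step, a 1.4-fold lower number from compound 1 to compound 2 (0.14 log units; within the scatter), is hydrogen in place of methyl on an aromatic nitrogen, so it bears on this change only indirectly. Among the compounds with values here, it shows one small edit elsewhere in the molecule leaving the number within the scatter, and no measured step touches the phenyl group. On that thin evidence, no step beyond the scatter is expected in this assay, and no direction can be favoured. The expected step is a 1.1-fold lower number from compound 2 to compound 3 (0.06 log units; within the scatter). For compound 3 the estimated value is 40000 nM, with an expected range of 16000 nM to 90000 nM.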

Compound 3, half-maximal inhibitory concentration: 35500 nM
Estimate against measurement, compound 3: 1.1-fold (0.05 log units) above; the range from low to high includes it.
By their numbers in this assay, from the lowest: compounds 3, 2 and 1 (each within the scatter of the next).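

For the compounds shown here, compound 3 gives the first reading on the phenyl group itself. In this assay, the step is a 1.3-fold lower number from compound 2 to compound 3 (0.11 log units; within the scatter), so at this place, para to a large group, adding chloro leaves compound 3 level with compound 2. The earlier step, a 1.4-fold lower number from compound 1 to compound 2 (0.14 log units; within the scatter), concerned an aromatic nitrogen and said nothing about this ring, whereas there is now one single-place edit at each of these two sites, and neither moves the number beyond the scatter. Nothing available accounts for this result or gives any measured property of the chloro group here.

The compounds shown leave open whether a different group in place of the chloro, such as an amine, a methoxy group or a carboxylic acid, would produce a step beyond the scatter, since chloro is the only group shown on this phenyl ring. They also leave open whether chloro elsewhere on that ring would behave as it does here, and whether 4-chlorophenyl would stay level when paired with the methyl group of compound 1.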